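Pyrazole ureas on breast cancer cells: a benzamide variant

The source may report more compounds than this note shows. Statements on the series, on what has been measured and on what is new or still open speak of the compounds shown alone.

Of the compounds shown here, three have been tested in a functional assay on MCF7 cells (Homo sapiens) for inhibition, read by sulforhodamine B assay, with a stated time of 48 h (a lower number here means that less compound is tolerated, a higher number that more compound is tolerated), and none has given a number. Compound 1 `O=C(Nc1cccc(-n2cc(-c3ccncc3)c(-c3ccc(Cl)c(O)c3)n2)c1)Nc1cccc(C(F)(F)F)c1` reaches only the limit of > 32500 nM, a limit of the assay and not a value. Compound 2 `COc1cc(-c2nn(-c3cccc(NC(=O)Nc4cc(C(F)(F)F)cc(C(F)(F)F)c4)c3)cc2-c2ccncc2)ccc1Cl` likewise stops at the limit of > 50000 nM. Compound 3 `COc1cc(-c2nn(-c3cccc(NC(=O)Nc4cccc(C(F)(F)F)c4)c3)cc2-c2ccncc2)ccc1Cl` shares the core of compound 1 and of compound 2; in this assay compound 3 also sits at the limit of > 50000 nM. Both measured steps are therefore unreadable: a step that the two limits leave unreadable from compound 1 to compound 3 and a step that the two limits leave unreadable from compound 2 to compound 3 cannot be sized, as the limit of > 32500 nM in this assay, at which 1 of the 3 values shown sits, and the limit of > 50000 nM in this assay, at which 2 of the 3 values shown sit, together show that every value reported so far is a limit.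

Compound 4 `COc1cc(-c2nn(-c3cccc(NC(=O)c4ccccc4)c3)cc2-c2ccncc2)ccc1Cl` differs from compound 3 at the carbonyl carbon: phenyl in place of (3-(trifluoromethyl)phenyl)amino on a carbonyl carbon. For the measured compounds named here, no measured step bears on this change in a readable way, and compound 3 itself is known only as a limit. The expected step is a number no higher from compound 3 to compound 4 (the limit leaves the size open), that is, no change beyond the scatter, with compound 4 most likely again reported only as a limit. Compound 4 is therefore estimated to give 50000 nM in this assay, with a range from 20000 nM to 100000 nM.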

Compound 4, concentration lethal to 50% of the cells: > 100000 nM
Compound 4: no number, only a limit (the forecaster's own chance of this, stated with the estimate: 75%); at least 2.0-fold (0.30 log units) between middle value and limit.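

In this assay compound 4 gives only a limit of the assay, > 100000 nM. For the compounds shown here, compound 3 is likewise known only as a limit, so no step between compound 3 and compound 4 can be read. What number any compound shown would give in this assay remains open.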